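The source may hold more compounds than are shown below. What is called first, only, known or untested is meant among the compounds shown, and "the series" means these compounds.

This set measures a physicochemical assay for solubility, measured as kinetic solubility (a lower number here means a less soluble compound, a higher number a more soluble compound), for three compounds built on one shared core, and the question is what a fourth will give. Compound 1 `COC(c1cc(Cl)c2c(c1Cl)C(=O)N(Cc1c(C)cc(C)[nH]c1=O)CC2)C1CCOCC1`, which carries a methoxy group and a six-membered saturated oxygen ring on the side chain, gives 57500 nM; 57200 nM (2 entries) in this assay; the two entries agree closely (the several entries of compound 1 in this assay, 57500 nM; 57200 nM (2 entries)). Compound 3 `COC(c1cc(Cl)c2c(c1Cl)C(=O)N(Cc1c(C)cc(C)[nH]c1=O)CC2)C1CCOC1`, with a methoxy group and a five-membered saturated oxygen ring, gives 415000 nM; 457000 nM; 439000 nM; 436000 nM (4 entries), again with tight repeats (the several entries of compound 3 in this assay, 415000 nM; 457000 nM; 439000 nM; 436000 nM (4 entries)). Among the compounds with values here, compound 2 `Cc1cc(C)c(CN2CCc3c(Cl)cc([C@@H](CO)[C@H]4CCCO4)c(Cl)c3C2=O)c(=O)[nH]1`, which carries a hydroxymethyl group and a five-membered saturated oxygen ring, gives 576000 nM; this is the only number for it, and two further entries gave no single number. Compound 2 therefore sits with compound 3 within the usual scatter, while compound 1 lies well apart from both.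

Compound 4 `Cc1cc(C)c(CN2CCc3c(Cl)cc([C@H](CO)[C@H]4CCOC4)c(Cl)c3C2=O)c(=O)[nH]1` is not yet measured. It differs from compound 2 in one place: a group of 8 heavy atoms (6 carbon, 2 oxygen; one five-membered non-aromatic ring with 1 hetero atom) in place of a group of 8 heavy atoms (6 carbon, 2 oxygen; one five-membered non-aromatic ring with 1 hetero atom), on an aromatic carbon. The two have the same atoms, joined differently, and both stereocentres are defined in each.

Within the data shown here, no measured pair differs in only this way, so the expectation rests on the closeness of compound 2 and compound 3. For compound 4 the expected step is a 1.2-fold lower number from compound 2 to compound 4 (0.06 log units; within the scatter), that is, no change beyond the scatter. Compound 4 is thus estimated at 500000 nM, within a range from 250000 nM to 1000000 nM.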

Compound 4, solubility: 570000 nM
Beside the measured number, compound 4's estimate is 1.1-fold (0.06 log units) below it; measured number inside the range.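

Within the data shown here, compound 2 and compound 4 are the first measured pair in this set that differ in only one place, so the group on this aromatic carbon, ortho to a chloro group, can now be compared directly. In this assay the exchange gives a 1.0-fold lower number from compound 2 to compound 4 (0.00 log units; within the scatter), so joining the same atoms differently, with both stereocentres defined in each compound, leaves the two compounds level at this position, a conclusion that earlier could only be inferred from less direct comparisons. The repeat entries available belong to other compounds and offer no explanation of why these two read alike.

Still open, going by these compounds, is whether a hydroxymethyl group paired with a six-membered saturated oxygen ring would read like compound 2 and compound 4 or nearer to compound 1, which gives 57500 nM; 57200 nM (2 entries) with its methoxy group and six-membered ring. Also open, on these data alone, is whether an amine or a carboxylic acid in place of the hydroxymethyl group would keep the number at this level in this assay.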